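Weak Cytotoxicity in Three Compounds and One Awaiting Measurement

The source may hold more compounds than are shown below. What is called first, only, known or untested is meant among the compounds shown, and "the series" means these compounds.

Measured compounds and values:
compound 1, `COc1ccc(N2CCN(CC(=O)N3CCN(c4nnc(-c5ccccc5)c(-c5ccccc5)n4)CC3)CC2)cc1`: > 910000 nM
compound 2, `Cc1ccc(-c2nnc(N3CCN(C(=O)CN4CCN(c5cccc(Cl)c5)CC4)CC3)nc2-c2ccc(C)cc2)cc1`: 859000 nM
compound 3, `COc1ccc(-c2nnc(N3CCN(C(=O)CN4CCN(c5ccccc5)CC4)CC3)nc2-c2ccc(OC)cc2)cc1`: > 863000 nM

In an ADME assay on NIH3T3 cells (Mus musculus) for cytotoxicity, read by MTT assay, with a stated time of 24 h (a higher number here means a weaker inhibitor, a lower number a stronger inhibitor), compound 3 gives > 863000 nM, which is a limit of the assay and not a number. Compound 1 likewise reaches a limit, > 910000 nM. Compound 2 gives 859000 nM. Thus two of the three values stand at limits, as recorded in the limit of > 863000 nM in this assay, at which 1 of the 3 values shown sits, and (the limit of > 910000 nM in this assay, at which 1 of the 3 values shown sits), and the third lies in the same region, so none of the three can be set apart from the others in this assay.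

The compound still to be measured is compound 4, `COc1ccc(-c2nnc(N3CCN(C(=O)CN4CCN(c5cccc(OC)c5)CC4)CC3)nc2-c2ccc(OC)cc2)cc1`. It differs from compound 3 by methoxy in place of hydrogen on an aromatic carbon, so that a phenyl becomes a 3-methoxyphenyl. Within the data shown here, no step between measured compounds that differ in one place is available, so the size of such a change cannot be read from the measured pairs. Given that compound 3 sits at a limit, > 863000 nM, and that the other two compounds sit close by, no movement beyond the scatter is expected in this assay. The expected step is a step that the limit leaves unreadable from compound 3 to compound 4. Compound 4 is therefore estimated at 900000 nM, with a range from 450000 nM to 2000000 nM, and most likely the assay will again return only a limit.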

Compound 4, half-maximal inhibitory concentration: > 821000 nM
Compound 4: no number, only a limit; the forecaster's own chance of this, stated with the estimate: 80%; the middle value lies beyond the limit too.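

In this assay compound 4 gives > 821000 nM which is a limit of the assay and not a number. Compound 3 gives > 863000 nM which is likewise a limit, so no step can be read between compound 3 and compound 4. The compounds shown leave open whether methoxy in place of hydrogen on an aromatic carbon moves the result in this assay at all.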